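This account rests on a few compounds, and the source may have more. Where it says the series, first, only, none or still open, it means among the compounds named here.

Compound 1 `C/C=C/C=C/C(=O)N(Cc1ccc(OC)c(O)c1)c1cc(OC)c(OC)c(OC)c1`: 180 nM
Compound 2 `C=C(C)C(=O)N(Cc1ccc(OC)c(O)c1)c1cc(OC)c(OC)c(OC)c1`: 200 nM

Of the compounds shown here, two have been measured. Both share the same core and differ only in the group attached to the carbonyl carbon. In a functional assay on KYSE-450 cells (Homo sapiens) for inhibition, read by MTT assay, with a stated time of 48 h (a higher number here means a weaker inhibitor, a lower number a stronger inhibitor), compound 1 gives 180 nM, and compound 2 gives 200 nM. Compound 2 therefore has the higher of the two numbers, but the gap to compound 1 is small: the step of a 1.1-fold higher number from compound 1 to compound 2 (0.05 log units; within the scatter) lies within the scatter, so the two cannot be told apart on these data.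

Compound 3 `COc1ccc(CN(C(=O)CN=[N+]=[N-])c2cc(OC)c(OC)c(OC)c2)cc1O` keeps the core of compound 2 and again alters the group on the carbonyl carbon: azidomethyl in place of 1-methylethenyl on a carbonyl carbon. Among the compounds with values here, the only measured step that touches this position, a 1.1-fold higher number from compound 1 to compound 2 (0.05 log units; within the scatter), showed no effect beyond the scatter, though the group entering here contains nitrogen rather than carbon alone, which the measured pair did not test. On that basis the step of a 1.4-fold higher number from compound 2 to compound 3 (0.15 log units; within the scatter) is expected to be small, in no firm direction. Compound 3 is estimated at 280 nM in this assay, with a range from 100 nM to 900 nM.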

Compound 3, half-maximal inhibitory concentration: 160 nM
For compound 3 the middle estimate is 1.8-fold (0.24 log units) above the measured one; low and high end bracket the measured number.
By their numbers in this assay, from the lowest: compounds 3, 1 and 2 (each within the scatter of the next).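

In this assay, within the data shown here, the azidomethyl group brings nitrogen onto this position for the first time, yet the step is only a 1.3-fold lower number from compound 2 to compound 3 (0.10 log units; within the scatter), and measured against the penta-1,3-dien-1-yl group it reads a 1.1-fold lower number from compound 1 to compound 3 (0.05 log units; within the scatter). All three compounds therefore sit within the scatter of one another, so on a carbonyl carbon bonded to the amide-type nitrogen, swapping a group of carbon alone for one made mostly of nitrogen gives no change that this assay can detect. No measurement here bears on why the values stay so close, so the result stands as an observation without an explanation.

What the compounds shown leave open is whether any group at this position can move the number beyond the scatter, for example an amine, a carboxylic acid or a group carrying a ring. All three compounds also share one core, so they say nothing about how much the other parts of the molecule contribute, such as the hydroxyl group on the shared core.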